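This account rests on a few compounds, and the source may have more. Where it says the series, first, only, none or still open, it means among the compounds named here.

Measured so far in a functional assay on A549 cells (Homo sapiens) for cytotoxicity, read by MTT assay, with a stated time of 72 h; on this read-out higher numbers stand for weaker inhibition and lower numbers for stronger inhibition:
compound 1 `CN(C)CCn1cnnc1-c1cc(Oc2ccc(NC(=O)N/N=C/c3cc(C(C)(C)C)cc(C(C)(C)C)c3O)cc2F)ccn1`, which gives 980 nM;
compound 2 `COc1ccc(OC)c(/C=N/NC(=O)Nc2ccc(Oc3ccnc(-c4nncn4CCN(C)C)c3)c(F)c2)c1`, which gives 1950 nM;
compound 3 `CN(C)CCn1cnnc1-c1cc(Oc2ccc(NC(=O)N/N=C/c3ccc(O)c(Br)c3)cc2F)ccn1`, which gives 1370 nM.

Compound 3 holds the second highest of these three numbers, yet both of the others lie within the scatter of it, so no order among them can be claimed. Compound 4 `CN(C)CCn1cnnc1-c1cc(Oc2ccc(NC(=O)N/N=C/c3ccc(F)cc3F)cc2F)ccn1` differs from compound 3 by 2,4-difluorophenyl in place of 3-bromo-4-hydroxyphenyl on a carbon with a double bond to nitrogen. Within the data shown here, only one measured step bears on this place: a 1.4-fold lower number from compound 2 to compound 3 (0.15 log units; within the scatter), an exchange of one ring for another at the same carbon that left the number within the scatter. Compound 4 is therefore expected to show a 1.0-fold higher number from compound 3 to compound 4 (0.01 log units; within the scatter) in this assay, with no direction beyond the scatter. Compound 4 is estimated at 1400 nM, within a range of 600 nM to 3300 nM.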

Compound 4, half-maximal inhibitory concentration: 1870 nM
For compound 4 the middle estimate is 1.3-fold (0.13 log units) below the measured one; the measured number falls inside the stated range.
By their numbers in this assay, from the lowest: compounds 1, 3, 4 and 2 (each within the scatter of the next).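

In this assay, the step from the hydroxyl-bearing ring gives a 1.4-fold higher number from compound 3 to compound 4 (0.14 log units; within the scatter), and the step from the dimethoxy ring gives a 1.0-fold lower number from compound 2 to compound 4 (0.02 log units; within the scatter). At this carbon, then, 3-bromo-4-hydroxyphenyl, with 1 hydrogen-bond donor and 1 hydrogen-bond acceptor, and 2,4-difluorophenyl, with 0 of each, cannot be told apart on this read-out, so three different rings now sit within the scatter. No measurement shown offers an explanation for this.

Still open, from the compounds shown here alone, is whether any ring substituent can move the number beyond the scatter. An amine or a carboxylic acid on the ring could test this, as could a longer chain in place of the ring.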